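The compounds below may be only part of what the source reports. "The series", "measured", "known", "first", "only" and "open" are said of these compounds alone.

Measured in a functional assay on HOP-62 cells (Homo sapiens) for inhibition, read by sulforhodamine B assay, with a stated time of 48 h; a higher number here means a weaker inhibitor of growth, a lower number a stronger inhibitor of growth:
compound 1 `COc1ccc(-c2nc3ccccn3c2/C=C/C(=O)c2cc(OC)c(OC)c(OC)c2)cc1`: 3620 nM
compound 2 `COc1cc(C(=O)/C=C/c2c(-c3cccs3)nc3ccccn23)cc(OC)c1OC`: 2880 nM
compound 3 `COc1cc(C(=O)/C=C/c2c(-c3ccc(F)cc3)nc3ncccn23)cc(OC)c1OC`: 3120 nM

Compound 3 stands second highest of the three numbers, nearest compound 2 and furthest from compound 1, both gaps within the scatter. Compound 4 `COc1ccc(-c2nc3ncccn3c2/C=C/C(=O)c2cc(OC)c(OC)c(OC)c2)cc1` differs from compound 3 by methoxy in place of fluoro on an aromatic carbon. Going by the values given here, no measured step covers this exchange; the only single-point step, a 1.3-fold lower number from compound 1 to compound 2 (0.10 log units; within the scatter), swaps a whole ring on an aromatic carbon and stays within the scatter. Compounds 1 and 3 carry methoxy and fluoro on different cores and their values also lie close together. A step in this assay of no more than the scatter is therefore expected, in no set direction. For compound 4 the expected value is 3300 nM, with a range of 1600 nM to 6800 nM, the estimated step being a 1.1-fold higher number from compound 3 to compound 4 (0.02 log units; within the scatter).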

Compound 4, concentration for 50% growth inhibition: 2830 nM
Estimate against measurement, compound 4: 1.2-fold (0.07 log units) above; the measured number falls inside the stated range.
By their numbers in this assay, from the lowest: compounds 4, 2, 3 and 1 (each within the scatter of the next).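

In this assay the exchange of 4-fluorophenyl to 4-methoxyphenyl can now be read directly on one core (a 1.1-fold lower number from compound 3 to compound 4 (0.04 log units; within the scatter)). Earlier compounds gave no direct reading of this change, only a ring swap on another core. Methoxy and fluoro, on an aromatic carbon para to a large group, read alike within the scatter on this core.

On these data alone, whether an amine or a carboxylic acid at this place would also read alike remains open. No measurement shown bears on why methoxy and fluoro read alike.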